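The compounds below may be only part of what the source reports. "The series", "measured", "known", "first", "only" and "open" are said of these compounds alone.

For the measured compounds named here, compound 1 (`CCOC(=O)c1cc(CCl)nn1[C@@H]1O[C@H](COC(C)=O)[C@@H](OC(C)=O)[C@H]1OC(C)=O`) is one of only two compounds measured so far. In a functional assay on HeLa cells (Homo sapiens) (a lower number here means that less compound is needed, a higher number that more compound is needed for the effect), compound 1 gives 32 ug/mL, the higher of the two numbers, so more of it is needed for the effect. The other measured compound, compound 2 (`CCOC(=O)c1cc(CI)nn1C1O[C@@H](COC(C)=O)[C@H](OC(C)=O)[C@@H](OC(C)=O)[C@@H]1OC(C)=O`), gives 2.5 ug/mL, a gap beyond the usual scatter. Compound 3 (`CCOC(=O)c1cc(CI)nn1[C@@H]1O[C@H](COC(C)=O)[C@@H](OC(C)=O)[C@H]1OC(C)=O`) keeps the rest of compound 1 and makes one change: iodo in place of chloro on a saturated chain carbon bound to an aromatic carbon. Iodo takes the place of chloro on a saturated chain carbon bound to an aromatic carbon, turning chloromethyl into iodomethyl.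

Going by the values given here, no measured pair isolates this swap, since compound 2 differs from compound 1 in more than one place. Still, compound 2 also carries iodomethyl and gives 2.5 ug/mL, so a moderate to large step toward a lower number in this assay seems likely, though perhaps not the whole gap. The estimated step, a 5.3-fold lower number from compound 1 to compound 3 (0.73 log units; beyond the scatter), is expected to lie beyond the scatter. For compound 3 the expected value is 6 ug/mL, with an estimated range of 1.5 ug/mL to 24 ug/mL.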

Compound 3, concentration for half-maximal effect: 5.5 ug/mL
Estimate against measurement, compound 3: 1.1-fold (0.04 log units) above; the measured number falls inside the stated range.
By their numbers in this assay, from the lowest: compound 2; then compound 3; then compound 1.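

For the compounds shown here, this is the first pair that differs in one place only, so the effect of the halogen can now be read on its own. With the rest of compound 1 unchanged, turning chloromethyl into iodomethyl gives a 5.8-fold lower number from compound 1 to compound 3 (0.76 log units; beyond the scatter) in this assay, which means that less compound is needed for the effect. The earlier comparison of compound 1 with compound 2 could not show this, as those two differ in more than one place, whereas this step shows that the halogen on a saturated chain carbon bound to an aromatic carbon matters by itself, but nothing available explains why the swap has this effect.

Still open, from the compounds shown here alone, is whether any halogen is needed at this place, and where a bromomethyl, a plain methyl or an aminomethyl group would fall relative to the chloromethyl and iodomethyl compounds. Also open, going by these compounds, is how much the other differences between compound 2 and compound 3 contribute to their numbers, and whether the swap from chloromethyl to iodomethyl would give a step of similar size on the core of compound 2.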